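Ring amine variation on the shared core, next step

The source may report more compounds than this note shows. Statements on the series, on what has been measured and on what is new or still open speak of the compounds shown alone.

Measured so far in a functional assay on HEK293 cells for activation of melanin-concentrating hormone receptor 1 (Rattus norvegicus), read by inositol phosphate accumulation; a lower number here means that less compound is needed, a higher number that more compound is needed for the effect:
compound 1 `O=C(CCc1ccc(C(F)(F)F)cc1)Nc1ccc2nc(N3CCCCC3)ccc2c1` gives 110 nM
compound 2 `O=C(CCc1ccc(C(F)(F)F)cc1)Nc1ccc2nc(N3CC4CCC3C4)ccc2c1` gives 150 nM
compound 3 `CN(c1ccc2cc(NC(=O)CCc3ccc(C(F)(F)F)cc3)ccc2n1)C1CCCC1` gives 350 nM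

Compound 3 stands highest of the three numbers in this assay; the step of a 3.2-fold higher number from compound 1 to compound 3 (0.50 log units; beyond the scatter) and the step of a 2.3-fold higher number from compound 2 to compound 3 (0.37 log units; beyond the scatter) are both modest but beyond the scatter, while a 1.4-fold higher number from compound 1 to compound 2 (0.13 log units; within the scatter) lies within it. Compound 4 `CC1CCCN1c1ccc2cc(NC(=O)CCc3ccc(C(F)(F)F)cc3)ccc2n1` changes the same position: 2-methylpyrrolidin-1-yl in place of cyclopentyl(methyl)amino on an aromatic carbon. The entering group is again a five-membered non-aromatic ring with one hetero atom, closer in kind to the amines of compounds 1 and 2 than to the open cyclopentyl(methyl)amino of compound 3. The step from compound 3 is therefore expected to go down, roughly reversing a 3.2-fold higher number from compound 1 to compound 3 (0.50 log units; beyond the scatter), as a 2.3-fold lower number from compound 3 to compound 4 (0.37 log units; beyond the scatter). For compound 4 in this assay the estimate is 150 nM, range 70 nM to 350 nM.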

Compound 4, half-maximal effective concentration: 270 nM
The estimate for compound 4 lay 1.8-fold (0.26 log units) below the measured number; measured number inside the range.
By their numbers in this assay, from the lowest: compounds 1, 2, 4 and 3 (each within the scatter of the next, the first and the last beyond it).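

In this assay, 2-methylpyrrolidin-1-yl in place of cyclopentyl(methyl)amino makes no readable difference (a 1.3-fold lower number from compound 3 to compound 4 (0.11 log units; within the scatter)), and the step from the other two-ring amine also stays inside the scatter (a 1.8-fold higher number from compound 2 to compound 4 (0.26 log units; within the scatter)). Against piperidin-1-yl, the same group does separate (a 2.5-fold higher number from compound 1 to compound 4 (0.39 log units; beyond the scatter)). A five-membered ring amine on this carbon therefore does not by itself reach the number of compound 1, as compound 4 shows.

Open, from the compounds shown here alone, is whether unsubstituted pyrrolidin-1-yl or morpholin-4-yl would stand with compound 1 or with compound 4. Nothing shown bears on the cause of these steps.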